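Swapping Chloro for Nitro in an Antiproliferative Series

The source may hold more compounds than are shown below. What is called first, only, known or untested is meant among the compounds shown, and "the series" means these compounds.

In a functional assay on HeLa cells (Homo sapiens) for antiproliferative activity, read by cell counting, with a stated time of 2 days (a lower number here means a stronger inhibitor, a higher number a weaker inhibitor), compound 1 `COc1ccc(Nc2nc(N)c(C(=O)c3ccc(Cl)cc3)s2)cc1` gives 83 nM. Compound 3 `COc1cc(C(=O)c2sc(Nc3ccc(C)cc3)nc2N)cc(OC)c1OC` gives 86 nM, which lies within the usual scatter of the result for compound 1, so the two cannot be told apart. Compound 2 `Nc1nc(Nc2ccc(Cl)cc2)sc1C(=O)c1ccccc1` reads > 10000 nM, and this is a limit of the assay rather than a number.

The next compound to be tested is compound 4 `COc1ccc(Nc2nc(N)c(C(=O)c3ccc([N+](=O)[O-])cc3)s2)cc1`, in which nitro takes the place of chloro on an aromatic carbon, para to a large group: nitro in place of chloro on an aromatic carbon. For the measured compounds named here, no measured pair here differs in one place only, so the size of this step has no direct precedent. Compound 2, with its limit of > 10000 nM, shows that not every relative keeps a low number, so a weaker result seems the likelier direction. The expected change is a moderate weakening beyond the scatter, a 3.6-fold higher number from compound 1 to compound 4 (0.56 log units; beyond the scatter). For compound 4 the estimated value in this assay is 300 nM, with an expected range of 40 nM to 3000 nM.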

Compound 4, half-maximal inhibitory concentration: 350 nM
Beside the measured number, compound 4's estimate is 1.2-fold (0.07 log units) below it, and the stated range covers the measured number.
By their numbers in this assay, from the lowest: compounds 1 and 3 (each within the scatter of the next); then compound 4. At a limit, above all of these: compound 2.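

For the compounds shown here, this is the first change that can be read at a single place: in this assay, nitro in place of chloro on an aromatic carbon, para to a large group, gives a 4.2-fold higher number from compound 1 to compound 4 (0.62 log units; beyond the scatter). The number at this position therefore depends on the group that sits there, though the step is modest and compound 4 still gives a measured number. Compound 2 alone stands at a limit of the assay, which is not a number: the limit of > 10000 nM in this assay, at which 1 of the 4 values shown sits.

One step cannot show whether other groups at this carbon would keep the number near that of compound 1 or move it further. On these data alone, how fluoro, a nitrile or an amine would read there remains open, as does whether the same swap would give a similar step on the core of compound 3.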